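Adding a second chloro to compound 3: working notes

The compounds below may be only part of what the source reports. "The series", "measured", "known", "first", "only" and "open" are said of these compounds alone.

compound 1 `CN1C/C(=C\c2ccc(C#N)cc2)C(=O)/C(=C/c2ccccc2F)C1`: 11000 nM
compound 2 `CN1C/C(=C\c2ccc(F)cc2)C(=O)/C(=C/c2ccc(C#N)cc2)C1`: 20900 nM
compound 3 `CN1C/C(=C\c2ccc(Cl)cc2)C(=O)/C(=C/c2ccc(C#N)cc2)C1`: 16200 nM
compound 4 `CN1C/C(=C\c2ccc(C#N)cc2)C(=O)/C(=C/c2ccc(Cl)cc2Cl)C1`: not yet measured

In an ADME assay on L02 cells (Homo sapiens) for cytotoxicity, read by MTT assay, with a stated time of 24 h (on this read-out higher numbers stand for weaker inhibition and lower numbers for stronger inhibition), compound 3 gives 16200 nM, which cannot be separated from the other two values: a 1.5-fold higher number from compound 1 to compound 3 (0.17 log units; within the scatter) and a 1.3-fold lower number from compound 2 to compound 3 (0.11 log units; within the scatter). Compound 4 differs from compound 3 by chloro in place of hydrogen on an aromatic carbon, or 4-chlorophenyl to 2,4-dichlorophenyl. Among the measured compounds shown here, no measured step adds a group at this place. The closest evidence comes from the halogen changes, a 1.9-fold higher number from compound 1 to compound 2 (0.28 log units; within the scatter) and a 1.5-fold higher number from compound 1 to compound 3 (0.17 log units; within the scatter), and both stay within the scatter. No step beyond the scatter is therefore expected in this assay. The estimated step is a 1.4-fold lower number from compound 3 to compound 4 (0.13 log units; within the scatter). For compound 4 the expected value is 12000 nM, with an estimated range of 6000 nM to 24000 nM.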

Compound 4, half-maximal inhibitory concentration: 10800 nM
Estimate against measurement, compound 4: 1.1-fold (0.05 log units) above, and the stated range covers the measured number.
By their numbers in this assay, from the lowest: compounds 4, 1, 3 and 2 (each within the scatter of the next).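

In this assay, the step that adds a group at this place, chloro in place of hydrogen on an aromatic carbon ortho to a large group, is a 1.5-fold lower number from compound 3 to compound 4 (0.18 log units; within the scatter), and it lies within the scatter. The other two steps, a 1.9-fold lower number from compound 2 to compound 4 (0.29 log units; within the scatter) and a 1.0-fold lower number from compound 1 to compound 4 (0.01 log units; within the scatter), also lie within the scatter, so 2,4-dichlorophenyl cannot be separated from 4-fluorophenyl or 2-fluorophenyl here. No supporting measurement explains these values.
From the compounds shown here alone, whether an amine or a carboxylic acid on this aromatic carbon would give a step beyond the scatter remains open.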